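A few compounds are considered here, and "the series" means these few. Any claim that something is new, unique, unknown or untested is made for them only; others in the source may bear on it.

Of the compounds shown here, three with a shared core have been measured in a functional assay on CCRF-CEM cells (Homo sapiens) for inhibition, read by sulforhodamine B assay, with a stated time of 48 h; a lower number here means a stronger inhibitor of growth, a higher number a weaker inhibitor of growth. Compound 1, `Nc1cc(N)c2nc(-c3ccccc3)c(Oc3ccc(Cl)c(Cl)c3)nc2c1`, gives 2950 nM in this assay. Compound 2, `Nc1cc(N)c2nc(-c3ccccc3)c(NCc3ccc(Cl)c(Cl)c3)nc2c1`, gives 132 nM. Compound 3, `CCOC(=O)[C@H](CCC(=O)O)NC(=O)c1ccc(Sc2nc3cc(N)cc(N)c3nc2-c2ccccc2)cc1`, gives 4170 nM. On these numbers compound 2 stands lowest of the three: compound 1 sits a good deal higher, and compound 3 higher still, both gaps lying beyond the scatter of repeated measurements, so compound 2 is the strongest growth inhibitor of the set.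

The next compound, compound 4, `COc1ccc(CNc2nc3cc(N)cc(N)c3nc2-c2ccccc2)cc1`, keeps the core and the linking nitrogen of compound 2 and changes only the outer ring: 4-methoxyphenyl in place of 3,4-dichlorophenyl on a saturated chain carbon bound to a nitrogen on an aromatic ring. Among the compounds with values here, no pair of measured compounds differs in just this way, so there is no measured step to lean on; the three measured compounds differ from one another in the linker and the whole attached group at once, which gives no separate reading of what the outer ring alone contributes.

For that reason the expected step from compound 2 to compound 4 in this assay, a 2.3-fold higher number from compound 2 to compound 4 (0.36 log units; beyond the scatter), is taken as a modest weakening, with a wide range that also allows for no change beyond the scatter. Compound 4 is therefore estimated at 300 nM, expected to lie between 60 nM and 1500 nM.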

Compound 4, concentration for 50% growth inhibition: 3390 nM
The estimate for compound 4 lay 11-fold (1.05 log units) below the measured number; measured number outside the range, above it.
By their numbers in this assay, from the lowest: compound 2; then compounds 1, 4 and 3 (each within the scatter of the next).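

Within the data shown here, this is the first pair in the set that differs in one place only, so the outer ring can now be read on its own. In this assay, 4-methoxyphenyl in place of 3,4-dichlorophenyl on a saturated chain carbon bound to a nitrogen on an aromatic ring gives a 26-fold higher number from compound 2 to compound 4 (1.41 log units; beyond the scatter), a large step beyond the scatter, which shows that the shared core and the linking nitrogen do not by themselves set the level of growth inhibition and that the outer ring at this position counts heavily. No measurement shown here accounts for the size of this step.

The change swaps both the kind of group on the ring and where those groups sit, so the compounds shown leave open whether the step follows from losing the chlorine atoms, from gaining the methoxy group, or from both. As far as these compounds go, an unsubstituted phenyl or a 4-chlorophenyl on the same chain carbon would separate these readings, and whether the 3,4-dichlorophenyl keeps its advantage with a longer chain also remains open.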